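The source may report more compounds than this note shows. Statements on the series, on what has been measured and on what is new or still open speak of the compounds shown alone.

Notes on the series. Compound 1 `COc1ccccc1-n1nc(C)c2c1NC(=O)[C@H](C)S[C@@H]2c1ccc(Oc2ccccc2)cc1` and compound 2 `Cc1nn(-c2ccccc2I)c2c1C(c1ccc(Oc3ccccc3)cc1)SC(C)C(=O)N2` share a core and have both been run in an assay on isolated protein for agonist activity at Bile acid receptor (Homo sapiens), read by AlphaScreen, with a stated time of 30 min; on this read-out higher numbers stand for larger maximal responses and lower numbers for smaller maximal responses. In this assay compound 1 gives 37%, while compound 2 gives 130%. Compound 1 thus holds the lower of the two numbers, with compound 2 standing well beyond the scatter above it.

Compound 3 `Cc1nn(-c2ccccc2C(C)C)c2c1[C@@H](c1ccc(Oc3ccccc3)cc1)S[C@@H](C)C(=O)N2` has not yet been measured in this assay. Relative to compound 1 the change is isopropyl in place of methoxy on an aromatic carbon. Among the measured compounds shown here, no step between measured compounds covers this exchange, so nothing in the two values shown fixes its size or direction.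

Given only that compound 1 gives 37% and compound 2 gives 130%, an increase of moderate size is expected for compound 3, estimated as a number 43 percentage points higher from compound 1 to compound 3 (beyond the scatter). The expected value for compound 3 in this assay is 80%, within a range from 30% to 130%.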

Compound 3, largest response reached (reported as efficacy), in percent of the reference or control that the assay uses: 174%
Compound 3: middle estimate off by 94 percentage points, on the low side, and the stated range ends below it.
By their numbers in this assay, from the lowest: compound 1; then compound 2; then compound 3.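

In this assay, among the compounds shown here, the change from 2-methoxyphenyl to 2-isopropylphenyl gives a number 137 percentage points higher from compound 1 to compound 3 (beyond the scatter), the first direct reading of a single exchange at this position. The maximal response therefore depends strongly on the group held on this aromatic carbon, ortho to a large group, and an all-carbon isopropyl is accepted here with a large gain over methoxy. No separate measurement bears on the reason for this step.

The exchange removes a hydrogen-bond acceptor and adds a heavy atom at the same time, and the compounds shown leave open which of these differences, if either, goes with the gain. Also open, from the compounds shown here alone, is how the response would run with an ethyl group, a tert-butyl group, an amine or a carboxylic acid on this carbon.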